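The source may report more compounds than this note shows. Statements on the series, on what has been measured and on what is new or still open speak of the compounds shown alone.

Compound 1 `O=C(/C=C/c1ccccn1)c1nc2ccccc2o1`: > 100000 nM
Compound 2 `O=C(/C=C/c1ccncc1)c1nc2ccccc2[nH]1`: 710 nM
Compound 3 `COc1cccc(/C=C/C(=O)c2nc3ccccc3[nH]2)c1`: 580 nM

In a functional assay on HCT-116 cells (Homo sapiens) for antiproliferative activity, read by MTT assay, with a stated time of 48 h (a lower number here means a stronger inhibitor, a higher number a weaker inhibitor), compound 1 reads > 100000 nM, which is a limit of the assay and not a number. Compound 2, at 710 nM, and compound 3, at 580 nM, lie within the usual scatter of each other, so compound 2 cannot be ranked against compound 3.

Compound 4 `O=C(/C=C/c1cccnc1)c1nc2ccccc2[nH]1` has not yet been measured. It has the same atoms as compound 2, joined differently: pyridin-3-yl in place of pyridin-4-yl on a double-bonded chain carbon bound to a double-bonded chain carbon. This places pyridin-3-yl in place of pyridin-4-yl on a double-bonded chain carbon bound to a double-bonded chain carbon.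

Among the measured compounds shown here, no measured pair shows this exact change, so any forecast is only loose. Compound 3, with a different ring on that chain, gives 580 nM, so only a small shift, not clearly beyond the scatter, is expected in this assay. The estimated change is a 1.1-fold lower number from compound 2 to compound 4 (0.04 log units; within the scatter). For compound 4 the expected value is 650 nM, with an estimated range of 250 nM to 1800 nM.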

Compound 4, half-maximal inhibitory concentration: 15300 nM
Compound 4: the middle estimate sits 24-fold (1.37 log units) below what was measured, and the stated range ends below it.
By their numbers in this assay, from the lowest: compounds 3 and 2 (each within the scatter of the next); then compound 4. At a limit, above all of these: compound 1.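

In this assay, putting pyridin-3-yl in place of pyridin-4-yl on a double-bonded chain carbon bound to a double-bonded chain carbon gives a 22-fold higher number from compound 2 to compound 4 (1.33 log units; beyond the scatter). Among the compounds shown here, the two groups hold the same atoms and differ only in how they are joined, so this one place responds strongly to how the ring is attached, something the earlier compounds could not show, since no two of them differed in one place alone. Nothing measured here bears on why the step is this large.

The compounds shown leave open whether an amine or a carboxylic acid on the pyridin-3-yl ring would bring the number back towards that of compound 2. They also leave open whether a longer chain would keep a gap of this size.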